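The source may hold more compounds than are shown below. What is called first, only, known or untested is meant among the compounds shown, and "the series" means these compounds.

Measured in a functional assay on T98G cells (Homo sapiens) for cytotoxicity, read by MTT assay, with a stated time of 48 h (a lower number here means a stronger inhibitor, a higher number a weaker inhibitor), so far
- compound 1 `C/C(=N\NC(=S)Nc1ccccc1I)c1ccccn1` gives 8.09 nM
- compound 2 `C/C(=N/NC(=S)Nc1ccccc1F)c1ccccn1` gives 3.1 nM
- compound 3 `C/C(=N/NC(=S)Nc1ccccc1)c1ccccn1` gives 6.81 nM

Compound 3 lies within the scatter of compound 1, and both numbers are higher than that of compound 2. Compound 4 `C/C(=N/NC(=S)Nc1ccccc1I)c1ccccn1` puts iodo in place of hydrogen on an aromatic carbon, ortho to a large group iodo in place of hydrogen on an aromatic carbon in compound 3. Going by the values given here, the one measured step that bears on this is modest, a 2.2-fold higher number from compound 2 to compound 3 (0.34 log units; beyond the scatter) with hydrogen in place of fluoro on an aromatic carbon. Compound 1 also carries iodo, but with the opposite geometry at the carbon-nitrogen double bond, and it gives 8.09 nM in this assay as well. A small drop, probably none beyond the scatter, is therefore expected. The expected step is a 1.2-fold lower number from compound 3 to compound 4 (0.09 log units; within the scatter) in this estimate. Compound 4 is estimated at 5.5 nM with an expected range from 2.5 nM to 12 nM in this assay here.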

Compound 4, half-maximal inhibitory concentration: 8.09 nM
Beside the measured number, compound 4's estimate is 1.5-fold (0.17 log units) below it; the range from low to high includes it.
By their numbers in this assay, from the lowest: compound 2; then compounds 3, 1 and 4 (each within the scatter of the next).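

In this assay, iodo and hydrogen at this aromatic carbon, ortho to a large group, are not separated, with a 1.2-fold higher number from compound 3 to compound 4 (0.07 log units; within the scatter). Fluoro at the same place stands apart from iodo, with a 2.6-fold higher number from compound 2 to compound 4 (0.42 log units; beyond the scatter). Reversing the geometry at the carbon-nitrogen double bond shows no change at the digits printed from compound 1 to compound 4 (within the scatter), a comparison that isolates this single feature: the fact that compounds 1 and 4 differ only in the configuration as drawn

The compounds shown leave open whether chloro or bromo at this place would group with fluoro or with iodo. They also leave open how an amine or a methoxy group there would read.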